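This account rests on a few compounds, and the source may have more. Where it says the series, first, only, none or still open, it means among the compounds named here.

Three compounds have been measured in a physicochemical assay for solubility, using the shake flask method, in simulated intestinal fluid, measured as kinetic solubility, with a stated time of 2 h, at 25 degrees C, at pH 6.5; a lower number here means a less soluble compound, a higher number a more soluble compound:

compound 1, `Cc1nc(C(=O)OC2CC2)c(N)c2c1C(=O)N(Cc1ccccc1)C2=O`: 202000 nM
compound 2, `CNC(=O)c1nc(C)c2c(c1N)C(=O)N(Cc1ccccc1)C2=O`: 41000 nM
compound 3, `Cc1noc(-c2nc(C)c3c(c2N)C(=O)N(CC2CCNCC2)C3=O)n1`: 160000 nM

Compound 3 stands second highest of the three numbers. Its value sits within the scatter of compound 1, so the two cannot be told apart, while its value is clearly higher than that of compound 2, beyond the scatter.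

Compound 4, `Cc1noc(-c2nc(C)c3c(c2N)C(=O)N(Cc2ccc(S(C)(=O)=O)cc2)C3=O)n1`, differs from compound 3 in one place: 4-(methylsulfonyl)phenyl in place of piperidin-4-yl on a saturated chain carbon bound to an amide-type nitrogen in a ring. Going by the values given here, the one measured step, a 4.9-fold lower number from compound 1 to compound 2 (0.69 log units; beyond the scatter), concerns a change on a carbonyl carbon and not the group attached to the saturated chain carbon bound to the amide-type nitrogen, so no measured step covers the same kind of change. That step does show that a single swap of a group on this shared core can move the number by a modest amount beyond the scatter. On that basis the change from compound 3 to compound 4 is expected to give a modest lowering, a 3.6-fold lower number from compound 3 to compound 4 (0.55 log units; beyond the scatter), though the direction is uncertain. Compound 4 is therefore estimated at 45000 nM, within a range from 8000 nM to 200000 nM.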

Compound 4, solubility: < 5000 nM
Compound 4: only a limit was reported (the forecaster's own chance of this, stated with the estimate: 10%); middle value at least 9.0-fold (0.95 log units) away from the limit.
By their numbers in this assay, from the lowest: compound 2; then compounds 3 and 1 (each within the scatter of the next). At a limit, below all of these: compound 4.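

In this assay compound 4 gives < 5000 nM and that is a limit of the assay, not a number: the limit of < 5000 nM in this assay, at which 1 of the 4 values shown sits. Putting 4-(methylsulfonyl)phenyl in place of piperidin-4-yl gives an at least 32-fold lower number from compound 3 to compound 4 (1.50 log units; beyond the scatter) and this shows that the group on a saturated chain carbon bound to an amide-type nitrogen in a ring can carry a large step. Going by these compounds alone, the only earlier step, a 4.9-fold lower number from compound 1 to compound 2 (0.69 log units; beyond the scatter) and so modest in size, lay on a carbonyl carbon and said nothing about this place.

The swap changes several things at once, the ring type, the ring nitrogen and the methylsulfonyl group, and the compounds shown do not separate them. As far as these compounds go, whether a cyclohexyl ring, with carbon only, or a morpholine ring would stay close to compound 3 or fall toward compound 4 remains open.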